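From methyl to chlorine: one change on the ester side

The compounds below may be only part of what the source reports. "The series", "measured", "known", "first", "only" and "open" are said of these compounds alone.

In a functional assay on cells (T-cell, Mus musculus, strain BALB/c) for inhibition, read by MTT assay, with a stated time of 72 h (a lower number here means a stronger inhibitor, a higher number a weaker inhibitor), compound 1 `COC(=O)c1cc(O)ccc1OC(=O)COc1cc(O)c2c(=O)cc(-c3ccccc3)oc2c1` gives 29500 nM.
In this assay compound 2 `COC(=O)c1cccc(C)c1OC(=O)COc1cc(O)c2c(=O)cc(-c3ccccc3)oc2c1` gives 39100 nM.

Among the measured compounds shown here, compound 2 holds the higher of the two numbers, yet its only neighbour, compound 1, sits a 1.3-fold higher number from compound 1 to compound 2 (0.12 log units; within the scatter) away, so the two are indistinguishable. Compound 3 `COC(=O)c1c(Cl)cccc1OC(=O)COc1cc(O)c2c(=O)cc(-c3ccccc3)oc2c1` differs from compound 2 by a group of 11 heavy atoms (8 carbon, 2 oxygen, 1 chlorine; one six-membered aromatic ring of carbon only) in place of a group of 11 heavy atoms (9 carbon, 2 oxygen; one six-membered aromatic ring of carbon only), on an oxygen next to a carbonyl group. For the measured compounds named here, the only measured step at this position, a 1.3-fold higher number from compound 1 to compound 2 (0.12 log units; within the scatter), stayed within the scatter, so in this assay the expected step from compound 2 to compound 3 is a 1.1-fold lower number from compound 2 to compound 3 (0.05 log units; within the scatter), with no direction beyond the scatter. Compound 3 is therefore estimated at 35000 nM, expected to fall between 15000 nM and 80000 nM.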

Compound 3, half-maximal inhibitory concentration: 38900 nM
The estimate for compound 3 lay 1.1-fold (0.05 log units) below the measured number; the range from low to high includes it.
By their numbers in this assay, from the lowest: compounds 1, 3 and 2 (each within the scatter of the next).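

At this position, on an oxygen next to a carbonyl group, the 3-chloro-2-(methoxycarbonyl)phenyl group gives a 1.0-fold lower number from compound 2 to compound 3 (0.00 log units; within the scatter) and a 1.3-fold higher number from compound 1 to compound 3 (0.12 log units; within the scatter) in this assay. All three groups shown here now lie within the scatter of one another, so bringing in chlorine separates nothing in these numbers. Nothing measured here offers a reason for this.

Still open, going by these compounds, is whether an amine or a carboxylic acid on this ring, or a longer chain in place of the methoxycarbonyl group, would move the number beyond the scatter.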